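The source may hold more compounds than are shown below. What is called first, only, known or untested is meant among the compounds shown, and "the series" means these compounds.

Compound 2, `COc1cc(N(CC2CC2)c2ccc(F)c(Cl)c2)cnc1C(=O)[C@H]1C[C@@H]1C(=O)O`, gives 42.3 nM in an assay on isolated protein for inhibition of leukotriene C4 synthase (Homo sapiens), read by LC-MS, with stated times of 45 min and 20 min; a higher number here means a weaker inhibitor, a lower number a stronger inhibitor. For the measured compounds named here, only one other compound has been measured, compound 1, `COc1cc(N(CC2CC2)c2cccc(C(F)(F)F)c2)cnc1C(=O)[C@H]1C[C@@H]1C(=O)O`, which in this assay gives 52.4 nM, and the step of a 1.2-fold lower number from compound 1 to compound 2 (0.09 log units; within the scatter), so compound 2 stands side by side with compound 1 rather than apart from it. Compound 3, `COc1cc(N(CC2CC2)c2cc(Cl)c(F)cc2F)cnc1C(=O)[C@H]1C[C@@H]1C(=O)O`, differs from compound 2 by fluoro in place of hydrogen on an aromatic carbon. Going by the values given here, no measured step concerns the addition of a single fluoro to this phenyl ring; the only step measured, which exchanged one substitution pattern of that ring for another, stayed within the scatter, and it is the sole guide available. On that basis the expected step is a 1.1-fold lower number from compound 2 to compound 3 (0.02 log units; within the scatter), that is, none beyond the scatter. Compound 3 is therefore estimated at 40 nM in this assay, with an expected range from 18 nM to 90 nM.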

Compound 3, half-maximal inhibitory concentration: 27.6 nM
Estimate against measurement, compound 3: 1.4-fold (0.16 log units) above, and the stated range covers the measured number.
By their numbers in this assay, from the lowest: compounds 3, 2 and 1 (each within the scatter of the next).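

Adding a fluoro ortho to a large group, meta to a fluoro group and para to a chloro group leaves the result in this assay within the scatter (a 1.5-fold lower number from compound 2 to compound 3 (0.19 log units; within the scatter)), so this position accepts the added atom without a step that can be told from repeat measurement. The comparison that spans the whole ring change, 5-chloro-2,4-difluorophenyl against 3-(trifluoromethyl)phenyl, also stays within the scatter (a 1.9-fold lower number from compound 1 to compound 3 (0.28 log units; within the scatter)), and the three substitution patterns are not separated from one another. Nothing measured alongside these numbers bears on this result.

The compounds shown leave open whether fluoro alone is accepted at this position or whether a larger or different group, such as a nitrile, an amine or a methoxy group, would also be. For the compounds shown here, they also leave open whether the chloro group is needed on this ring, since no compound here carries only fluoro groups.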